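This account rests on a few compounds, and the source may have more. Where it says the series, first, only, none or still open, it means among the compounds named here.

Compound 1 `O=C(Nc1ccc(OCc2ccc(F)cc2)cc1)C1CCCNC1` and compound 2 `O=C(Nc1ccc(OCc2ccc(-c3ccccc3)cc2)cc1)C1CCCNC1` share one core, while compound 3 `N=C(N)N1CCCC(C(=O)Nc2cccc(OCc3ccc(F)cc3)c2)C1` and compound 4 `N=C(N)N1CCCC(C(=O)Nc2cccc(OCc3ccc(-c4ccccc4)cc3)c2)C1` share another; the difference between the two cores is not broken down here. In a functional assay on a cell-free system (Platelet, plasma, Homo sapiens) for inhibition (on this read-out lower numbers stand for stronger inhibition and higher numbers for weaker inhibition), compound 1 gives 116000 nM, and compound 2 gives 125000 nM. The change between them is phenyl in place of fluoro on an aromatic carbon, and it made a 1.1-fold higher number from compound 1 to compound 2 (0.03 log units; within the scatter). Compound 3 gives 274000 nM in this assay, the highest of the three measured numbers, beyond the scatter from both others. The change from compound 3 to compound 4 is phenyl in place of fluoro on an aromatic carbon, the same change at the same place on the other core. Since the earlier step of a 1.1-fold higher number from compound 1 to compound 2 (0.03 log units; within the scatter) stayed within the scatter, the step to compound 4 is expected to be about a 1.1-fold higher number from compound 3 to compound 4 (0.04 log units; within the scatter). Compound 4 is therefore estimated at 300000 nM in this assay, most likely between 150000 nM and 600000 nM.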

Compound 4, half-maximal inhibitory concentration: 1000000 nM
The estimate for compound 4 lay 3.3-fold (0.52 log units) below the measured number; measured number above the stated range.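

Putting phenyl in place of fluoro gave a 3.6-fold higher number from compound 3 to compound 4 (0.56 log units; beyond the scatter) in this assay, so the size of the step did not carry over from one core to the other: the same change on two cores in this assay, a 1.1-fold higher number (0.03 log units; within the scatter) from compound 1 to compound 2 and a 3.6-fold higher number (0.56 log units; beyond the scatter) from compound 3 to compound 4, 3.4-fold (0.53 log units) apart, beyond the scatter of two such steps

For these two pairs, then, the step measured on one core was a poor guide to the step on the other. Two pairs do not show which difference between the cores matters, or whether other changes at this place would also diverge.

From the compounds shown here alone, it remains open how a methyl or methoxy group in place of fluoro would behave on each core. Also open, going by these compounds, is whether such groups would give steps as far apart as those seen with phenyl.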